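This account rests on a few compounds, and the source may have more. Where it says the series, first, only, none or still open, it means among the compounds named here.

Of the compounds shown here, three have been measured in an assay on HEK293 cells for agonist activity at transient receptor potential cation channel subfamily M member 8 (Homo sapiens), read by fluorescence and calcium flux, with a stated time of 15 min; on this read-out higher numbers stand for an effect only at larger amounts of compound and lower numbers for an effect already at smaller amounts. Compound 1 `CCN(Cc1c[nH]nn1)C(=O)COc1ccc(C)cc1` gives 31100 nM, compound 2 `Cc1ccc(OCC(=O)N(Cc2cccs2)c2ccnn2C)cc1` gives 422 nM, and compound 3 `COc1ccc(OCC(=O)N(Cc2cccs2)c2ccn[nH]2)cc1` gives 3.7 nM. Compound 2 therefore holds the second highest number of the three: compound 1 sits above it by a margin well beyond the scatter, and compound 3 sits below it by a margin also beyond the scatter. Compound 4 `Cc1ccc(OCC(=O)N(Cc2cccs2)c2c(C)n[nH]c2C)cc1` has not yet been measured. It differs from compound 2 in a single place: 3,5-dimethyl-1H-pyrazol-4-yl in place of 1-methyl-1H-pyrazol-5-yl on an amide-type nitrogen. For the measured compounds named here, no pair of measured compounds isolates this change, so its likely effect has to be judged from the three numbers alone. Compound 3 shows that a far lower number is reachable within this series, but it differs from compound 2 in more than one place, so it does not settle the question. For compound 4 the step of a 1.4-fold lower number from compound 2 to compound 4 (0.15 log units; within the scatter) is expected to stay within the scatter, leaning toward a lower number. Compound 4 is thus estimated at 300 nM, with a range from 40 nM to 2500 nM.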

Compound 4, half-maximal effective concentration: 0.3 nM
The estimate for compound 4 lay 1000-fold (3.00 log units) above the measured number; the whole stated range lies above it.
By their numbers in this assay, from the lowest: compound 4; then compound 3; then compound 2; then compound 1.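

In this assay, changing only the group on the amide-type nitrogen gives a 1400-fold lower number from compound 2 to compound 4 (3.15 log units; beyond the scatter), so this position can strongly affect the concentration needed for a response, even when one five-membered aromatic ring with 2 hetero atoms replaces another. The change is not a single small edit: 3,5-dimethyl-1H-pyrazol-4-yl carries 1 hydrogen-bond donor where 1-methyl-1H-pyrazol-5-yl has 0, adds a heavy atom, and differs in how its methyl groups and point of attachment are arranged. No supporting evidence here explains the size of this step. These compounds therefore leave open which of those differences matters. A 1H-pyrazol-4-yl group without the methyl groups, or a 3,5-diethyl-1H-pyrazol-4-yl group with longer chains, would help separate them.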